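The compounds below may be only part of what the source reports. "The series", "measured", "known", "first", "only" and "open" are said of these compounds alone.

Measured compounds:
compound 1, `CC(C)Cc1ccc(C(=O)/C=C/c2ccc(C(=O)O)cc2)cc1`
compound 2, `COC(=O)c1cc(-c2cccc(NC(=O)c3ccc(/C=C/C(=O)c4cccc(C(F)(F)F)c4)cc3)c2)on1`

In an ADME assay on Vero cells (Chlorocebus sabaeus) for cytotoxicity, read by MTT assay, with a stated time of 72 h (on this read-out lower numbers stand for higher toxicity in this test and higher numbers for lower toxicity in this test), compound 1 gives < 10 ug/mL, which is a limit of the test rather than a number. In this assay compound 2 gives > 20 ug/mL, likewise a limit. Compound 2 therefore stands at the limit of > 20 ug/mL in this assay, at which 1 of the 2 values shown sits, and compound 1 at the limit of < 10 ug/mL in this assay, at which 1 of the 2 values shown sits. Compound 3, `COC(=O)c1cc(-c2cccc(NC(=O)c3ccc(/C=C/C(=O)c4ccc(C)c([N+](=O)[O-])c4)cc3)c2)on1`, differs from compound 2 in one place: 4-methyl-3-nitrophenyl in place of 3-(trifluoromethyl)phenyl on a carbonyl carbon. Within the data shown here, no measured pair of this kind exists, so in this assay a step no larger than the usual scatter is expected, in no set direction. The expected step is a step that the limit leaves unreadable from compound 2 to compound 3. For compound 3 the estimate is 25 ug/mL, between 10 ug/mL and 60 ug/mL.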

Compound 3, half-maximal cytotoxic concentration: > 80 ug/mL
Compound 3 was reported as a limit (the forecaster's own chance of this, stated with the estimate: 60%); middle value at least 3.2-fold (0.50 log units) away from the limit.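

Among these compounds, compound 2 and compound 3 are each reported only as a limit of the test, so no step between them can be read. Left open is how far 4-methyl-3-nitrophenyl in place of 3-(trifluoromethyl)phenyl shifts toxicity to these cells.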